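The source may hold more compounds than are shown below. What is called first, only, known or untested is meant among the compounds shown, and "the series" means these compounds.

Measured compounds:
compound 1 `COc1ccc(-c2cn(-c3ccc(O)c(C(=O)O)c3)nn2)cc1` — 9% in a functional assay on CCRF-CEM cells (Homo sapiens) for inhibition, read by MTT assay, with a stated time of 2 days, tested at 10 uM; on this read-out lower numbers stand for less inhibition and higher numbers for more inhibition at the one concentration tested (going by the name of the read-out)
compound 2 `COC(=O)c1cc(-n2cc(-c3ccc(OC)cc3)nn2)ccc1O` — 16% in this assay
compound 3 `COc1ccccc1-c1cn(-c2ccc(O)c(C(=O)O)c2)nn1` — 9% in this assay

Compound 4 `COC(=O)c1cc(-n2cc(-c3ccccc3OC)nn2)ccc1O` has not been measured in this assay. It is related to compound 3 by the difference (methyl in place of hydrogen on an oxygen next to a carbonyl group). The same change connects compound 1 to compound 2, given as methyl in place of hydrogen on an oxygen next to a carbonyl group; both place descriptions read the same word for word, so the change is the same in both pairs. The cores of compound 1 and compound 3 share the same atoms joined differently, and that difference between the two cores is not broken down here.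

The measured instance of the change gave a number 7 percentage points higher from compound 1 to compound 2 (within the scatter), a step that lies within the scatter. Compound 3 stands level with compound 1 at the digits reported, and all three measured values lie within the scatter of one another, so no ordering among them is claimed.

Because the step of a number 7 percentage points higher from compound 1 to compound 2 (within the scatter) is within the scatter, the same change from compound 3 is expected to move the number only slightly, estimated as a number 5 percentage points higher from compound 3 to compound 4 (within the scatter). In this assay the expected value for compound 4 is 14%, expected to fall between 2% and 28%.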

Compound 4, a percentage reported as inhibition, at one concentration (the size of the read-out at that concentration, not a potency): 6%
Compound 4: the middle estimate sits 8 percentage points above what was measured, and the stated range covers the measured number.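

In this assay, carboxy to methoxycarbonyl on the core bearing 2-methoxyphenyl gives a number 3 percentage points lower from compound 3 to compound 4 (within the scatter), and among the methyl esters, 2-methoxyphenyl in place of 4-methoxyphenyl gives a number 10 percentage points lower from compound 2 to compound 4 (within the scatter). Set beside each other, the two instances of the ester change show no difference between the cores that stands clear of the scatter: the same change on two cores in this assay, a number 7 percentage points higher (within the scatter) from compound 1 to compound 2 and a number 3 percentage points lower (within the scatter) from compound 3 to compound 4, 10 percentage points apart, within the scatter of two such steps This shows only that the change produced no step beyond the scatter on either core; it does not establish a size or a direction for the change, and it does not show that the change would carry over equally to a core where the step is large enough to read.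

The compounds shown leave open whether anything at this oxygen other than hydrogen or methyl, such as an ethyl group or a longer chain, would give a step beyond the scatter. They also leave open whether an amide in place of the carboxylic acid, or an amine on the phenyl ring in place of methoxy, would separate from these values.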